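Small bicyclic amine swap at the chain carbon

The source may report more compounds than this note shows. Statements on the series, on what has been measured and on what is new or still open speak of the compounds shown alone.

Compound 3 `COc1ccc2[nH]c(C(=O)N3CC(=O)N(Cc4ccccc4)[C@@H](CN4CC5(CCC5)C4)C3)cc2c1` carries a group of 7 heavy atoms (6 carbon, 1 nitrogen; one four-membered non-aromatic ring of carbon only, one four-membered non-aromatic ring with 1 hetero atom) on a saturated chain carbon bound to a saturated ring carbon. In a physicochemical assay for solubility, read by spectrophotometry, in phosphate buffer, with a stated time of 2 h, at pH 7.4 (a higher number here means a more soluble compound, a lower number a less soluble compound), compound 3 gives 60700 nM. Compound 2 `COc1ccc2[nH]c(C(=O)N3CC(=O)N(Cc4ccccc4)[C@@H](CN4CCN(c5ccccn5)CC4)C3)cc2c1` gives 30200 nM in this assay, and the step of a 2.0-fold higher number from compound 2 to compound 3 (0.30 log units; within the scatter) lies within the scatter, so the two numbers are not separated. Compound 1 `COc1ccc2[nH]c(C(=O)N3CC(=O)N(Cc4ccccc4)[C@@H](CN4C(=O)c5ccccc5C4=O)C3)cc2c1` reaches only a limit in this assay, > 100000 nM (the limit of > 100000 nM in this assay, at which 1 of the 3 values shown sits). The step of an at least 1.6-fold lower number from compound 1 to compound 3 (0.21 log units; that floor lies within the scatter) has a floor inside the scatter.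

Compound 4 `COc1ccc2[nH]c(C(=O)N3CC(=O)N(Cc4ccccc4)[C@@H](CN4CC5CC5C4)C3)cc2c1` differs from compound 3 by a group of 6 heavy atoms (5 carbon, 1 nitrogen; one three-membered non-aromatic ring of carbon only, one five-membered non-aromatic ring with 1 hetero atom) in place of a group of 7 heavy atoms (6 carbon, 1 nitrogen; one four-membered non-aromatic ring of carbon only, one four-membered non-aromatic ring with 1 hetero atom), on a saturated chain carbon bound to a saturated ring carbon. The steps of an at least 1.6-fold lower number from compound 1 to compound 3 (0.21 log units; that floor lies within the scatter) and a 2.0-fold higher number from compound 2 to compound 3 (0.30 log units; within the scatter) changed this same position without a clear move, so no shift beyond the scatter is expected, the estimated step being a 1.1-fold lower number from compound 3 to compound 4 (0.04 log units; within the scatter). Compound 4 is therefore estimated at 55000 nM, expected between 25000 nM and 120000 nM.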

Compound 4, solubility: 17500 nM
Compound 4: middle estimate off by 3.1-fold (0.50 log units), on the high side, and the stated range ends above it.
By their numbers in this assay, from the lowest: compounds 4, 2 and 3 (each within the scatter of the next, the first and the last beyond it). At a limit, above all of these: compound 1.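

Within the data shown here, on the saturated chain carbon bound to a saturated ring carbon, the small amine groups are not interchangeable: a 3.5-fold lower number from compound 3 to compound 4 (0.54 log units; beyond the scatter), the first step beyond the scatter between two numbers that are not limits. Heavy atom count does not order these values, as the far larger group of the other compound stays unseparated in a 1.7-fold lower number from compound 2 to compound 4 (0.24 log units; within the scatter). The starting value of an at least 5.7-fold lower number from compound 1 to compound 4 (0.75 log units; beyond the scatter) is a limit, not a number: the limit of > 100000 nM in this assay, at which 1 of the 4 values shown sits.

As far as these compounds go, whether an open-chain amine such as diethylamine or a carboxylic acid on this carbon would fall within these values stays open. From the compounds shown here alone, what separates the two small groups also stays open.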